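This account rests on a few compounds, and the source may have more. Where it says the series, first, only, none or still open, it means among the compounds named here.

Compound 1 `CCn1nc(C)cc1C(=O)Nc1nc2cc(C(N)=O)cc(OC)c2n1CCCNC(=O)OCc1ccccc1` was tested in an assay for activation of interferon regulatory factor 3 (Homo sapiens), read by a luciferase reporter, with a stated time of 20 h; a lower number here means that less compound is needed, a higher number that more compound is needed for the effect. In this assay compound 1 gives only a limit of the assay, > 100000 nM, not a number. Going by the values given here, its one measured neighbour, compound 2 `COc1cc(C(N)=O)cc2nc(NC(=O)c3ccnn3C)n(CCCNC(=O)OCc3ccccc3)c12`, carries 1-methyl-1H-pyrazol-5-yl in place of 1-ethyl-3-methyl-1H-pyrazol-5-yl on a carbonyl carbon; in this assay compound 2 also gives only a limit, > 100000 nM. The step that the two limits leave unreadable from compound 1 to compound 2 therefore cannot be read, and all that is known is the limit of > 100000 nM in this assay, at which 2 of the 2 values shown sit. Compound 3 `CCn1nc(C)cc1C(=O)Nc1nc2cc(C(N)=O)cc(OC)c2n1CCCNC(=O)C(C)(C)C` differs from compound 1 in another place: tert-butyl in place of benzyloxy on a carbonyl carbon. Among the compounds with values here, no measured step bears on this change, so there is no basis to expect movement in this assay beyond the scatter, and compound 3 is expected to sit at the same limit as compound 1. The estimated step of a number no higher from compound 1 to compound 3 (the limit leaves the size open) is expected to be about flat. Compound 3 is thus estimated at 100000 nM, within 30000 nM to 300000 nM.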

Compound 3, half-maximal effective concentration: > 100000 nM
Compound 3 was reported as a limit; the forecaster's own chance of this, stated with the estimate: 85%; the middle value lies on the limit itself.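

In this assay compound 3, like compound 1, gives only a limit and not a number, so the step between them cannot be read: the limit of > 100000 nM in this assay, at which 3 of the 3 values shown sit. The compounds shown leave open how benzyloxy and tert-butyl compare, and whether any change to the shared core would give a measurable value in this assay.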